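A few compounds are considered here, and "the series" means these few. Any claim that something is new, unique, unknown or untested is made for them only; others in the source may bear on it.

Measured compounds:
compound 1, `CCOC(=O)[C@H](C)NC(=O)/C=C/c1ccc(O)c(O)c1`, giving 29700 nM in a functional assay, read by spectrophotometry, with a stated time of 30 min; on this read-out higher numbers stand for weaker inhibition and lower numbers for stronger inhibition
compound 2, `CCOC(=O)[C@H](CC(C)C)NC(=O)/C=C/c1ccc(O)c(OC)c1`, giving 56100 nM in this assay

In this assay compound 1 and compound 2 give numbers that lie within the scatter of each other, so neither stands apart from the other on what has been measured. Compound 3, `CCOC(=O)[C@H](CC(C)C)NC(=O)/C=C/c1ccc(O)c(O)c1`, has not yet been measured in this assay. Set against compound 1, compound 3 carries isopropyl in place of hydrogen on a saturated chain carbon, two bonds along the chain from an amide-type nitrogen and a carbonyl carbon. Going by the values given here, no measured pair shows this change on its own, so there is no step to lean on; the two numbers in hand suggest that changes around this part of the structure move this assay little. Compound 3 is therefore expected to give 35000 nM in this assay, within a range from 15000 nM to 80000 nM. The expected step is a 1.2-fold higher number from compound 1 to compound 3 (0.07 log units; within the scatter), which is estimated to stay within the scatter.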

Compound 3, half-maximal inhibitory concentration: 28600 nM
The estimate for compound 3 lay 1.2-fold (0.09 log units) above the measured number; the range from low to high includes it.
By their numbers in this assay, from the lowest: compounds 3, 1 and 2 (each within the scatter of the next).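

In this assay, isopropyl in place of hydrogen on a saturated chain carbon, two bonds along the chain from an amide-type nitrogen and a carbonyl carbon, amounts to a 1.0-fold lower number from compound 1 to compound 3 (0.02 log units; within the scatter), so at this position methyl and isobutyl cannot be told apart on this read-out. Compound 3 also isolates the second difference: hydrogen in place of methyl on an oxygen on an aromatic ring amounts to a 2.0-fold lower number from compound 2 to compound 3 (0.29 log units; within the scatter), and this too stays within the scatter, which the earlier pair, differing in two places at once, could not show. Nothing at hand explains either step.

As far as these compounds go, whether a longer chain or an amine on this same chain carbon would move the number beyond the scatter remains open. So does the outcome of a carboxylic acid in place of the ester.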